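Moving the thiophene attachment from compound 3 to compound 4

The compounds below may be only part of what the source reports. "The series", "measured", "known", "first", "only" and "open" are said of these compounds alone.

compound 1 `N=C(N)N/N=C/c1c(-c2cc(Cl)sc2Cl)nc2n1CCS2` gives 8710 nM
compound 2 `N=C(N)N/N=C/c1c(-c2cccs2)nc2sccn12` gives 12000 nM
compound 3 `N=C(N)N/N=C/c1c(-c2ccsc2)nc2n1CCS2` gives 25100 nM
compound 4 `N=C(N)N/N=C/c1c(-c2cccs2)nc2n1CCS2` has no measurement yet

In a functional assay on cells (Cancer cell lines, Homo sapiens) for inhibition (on this read-out higher numbers stand for weaker inhibition of growth and lower numbers for stronger inhibition of growth), compound 3 stands at 25100 nM as the highest of the three numbers, and both other compounds lie beyond the usual scatter from it on the lower side. Compound 4 carries thiophen-2-yl in place of thiophen-3-yl on an aromatic carbon, and the two compounds have the same atoms, joined differently: thiophen-2-yl in place of thiophen-3-yl on an aromatic carbon is the whole of the difference.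

Among the measured compounds shown here, one measured step bears on this place, a 2.9-fold higher number from compound 1 to compound 3 (0.46 log units; beyond the scatter) and it is modest, though it replaces 2,5-dichlorothiophen-3-yl and does not alter how the thiophene is attached. For the measured compounds named here, compound 2 is the only measured compound with thiophen-2-yl, at 12000 nM on a core that differs from that of compound 3, so it offers a hint and no direct comparison. Going by the values given here, no measured pair isolates the swap itself. A small shift toward a lower number is therefore expected, and the estimated step is a 1.5-fold lower number from compound 3 to compound 4 (0.17 log units; within the scatter) in this assay with real uncertainty in its direction. In this assay compound 4 is estimated at 17000 nM with an expected range of 8500 nM to 33000 nM around that figure.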

Compound 4, concentration for 50% growth inhibition: 19100 nM
Compound 4: middle estimate off by 1.1-fold (0.05 log units), on the low side; low and high end bracket the measured number.
By their numbers in this assay, from the lowest: compounds 1, 2, 4 and 3 (each within the scatter of the next, the first and the last beyond it).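

In this assay, the swap of thiophen-3-yl for thiophen-2-yl on this aromatic carbon can now be read directly on the shared core: it gives a 1.3-fold lower number from compound 3 to compound 4 (0.12 log units; within the scatter) and so, taken alone, the way the unsubstituted thiophene is attached does not move the read-out beyond the scatter. The comparison with the chlorinated compound, with thiophen-2-yl in place of 2,5-dichlorothiophen-3-yl, gives a 2.2-fold higher number from compound 1 to compound 4 (0.34 log units; beyond the scatter) and so both unsubstituted thiophenes now stand beyond the scatter from compound 1, which means that at this position the steps beyond the scatter go with the loss of the chlorines and not with the change of attachment. No measurement is at hand that bears on the reason for these steps.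

The compounds shown leave open whether a single chlorine on the thiophene would give the same step, and whether a phenyl ring, a methoxy group or an amine on this aromatic carbon would fall in the same range. They also leave open whether the change of attachment would read the same way on the core of compound 2.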